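A few compounds are considered here, and "the series" means these few. Any claim that something is new, unique, unknown or untested is made for them only; others in the source may bear on it.

Compound 1 `CCCON1C(=O)[C@@H](NC(=O)OCCCCC2CCCCC2)[C@@H]1C` gives 133 nM in an assay on HEK293 cells for inhibition of N-acylethanolamine-hydrolyzing acid amidase (Homo sapiens), read by fluorescence, with stated times of 10 min and 50 min; a lower number here means a stronger inhibitor, a higher number a weaker inhibitor.
Compound 2 `CCCCCCCON1C(=O)[C@@H](NC(=O)OCCCCC2CCCCC2)[C@@H]1C` gives 2230 nM in this assay.
Compound 3 `C[C@H]1[C@H](NC(=O)OCCCCC2CCCCC2)C(=O)N1OCCCCc1ccccc1` gives 1240 nM in this assay.

Compound 3 has the second highest number of the three; its nearest neighbour is compound 2, within the scatter, while compound 1 sits well below it. The three compounds differ only in the group on the oxygen of the shared core. Lengthening that group weakened inhibition: a 17-fold higher number from compound 1 to compound 2 (1.22 log units; beyond the scatter) and a 9.3-fold higher number from compound 1 to compound 3 (0.97 log units; beyond the scatter), whereas a 1.8-fold lower number from compound 2 to compound 3 (0.25 log units; within the scatter).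

Compound 4 `C[C@H]1[C@H](NC(=O)OCCCCC2CCCCC2)C(=O)N1Oc1ccccc1` takes this further by phenyl in place of 4-phenylbutyl on an oxygen. For the measured compounds named here, no measured step places an aromatic ring directly on that oxygen, so the evidence is indirect; the shortening points toward compound 1, which gives 133 nM. A lower number is therefore expected for compound 4, roughly 300 nM, between 80 nM and 1500 nM, that is, an expected step of a 4.1-fold lower number from compound 3 to compound 4 (0.62 log units; beyond the scatter).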

Compound 4, half-maximal inhibitory concentration: 23 nM
Compound 4: middle estimate off by 13-fold (1.12 log units), on the high side; the measured number lies below the stated range.
By their numbers in this assay, from the lowest: compound 4; then compound 1; then compounds 3 and 2 (each within the scatter of the next).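

Placing phenyl directly on this oxygen gives a lower number than any chain tested: replacing 4-phenylbutyl gives a 54-fold lower number from compound 3 to compound 4 (1.73 log units; beyond the scatter) and replacing heptyl gives a 97-fold lower number from compound 2 to compound 4 (1.99 log units; beyond the scatter) while even the shorter propyl gives way with a 5.8-fold lower number from compound 1 to compound 4 (0.76 log units; beyond the scatter) in this series. Compound 3 and compound 4 both carry the same aromatic ring, so the ring alone does not bring a high number; what differs is the chain that joins it to the oxygen. Nothing available explains this gain.

From the compounds shown here alone, whether benzyl, a pyridine ring or a chlorine-bearing phenyl on this oxygen would keep the number this low remains open.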